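Isobutoxy in place of methoxy on a bromomethyl chromone

This account rests on a few compounds, and the source may have more. Where it says the series, first, only, none or still open, it means among the compounds named here.

Compound 2 `CCc1cc(=O)c2ccc(OC)c(CBr)c2o1`: in a functional assay on KBVIN cells (Homo sapiens) for antiproliferative activity, read by sulforhodamine B assay, with a stated time of 72 h (on this read-out higher numbers stand for weaker inhibition of growth and lower numbers for stronger inhibition of growth), compound 2 gives > 33600 nM, which is a limit of the assay and not a number.
Compound 1 `Cc1cccc(CSc2ccc3c(C)cc(=O)oc3c2)c1`: in this assay compound 1 gives > 33700 nM, again a limit and not a number.

Going by the values given here, compound 2 therefore stands only at a limit, and the one further value shown, that of compound 1, is likewise a limit (the limit of > 33700 nM in this assay, at which 1 of the 2 values shown sits, (the limit of > 33600 nM in this assay, at which 1 of the 2 values shown sits)). Among the compounds with values here, neither compound gives a number, and no step between two measured compounds that differ in one place is available, so nothing shows how a change in one part of the molecule moves the read-out.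

Compound 3 `CCc1cc(=O)c2ccc(OCC(C)C)c(CBr)c2o1` differs from compound 2 by isopropyl in place of hydrogen on a saturated chain carbon bound to an oxygen on an aromatic ring. The rest of the molecule, including the bromomethyl group and the core shared with compound 2, is unchanged.

With compound 2 sitting at a limit, the expected step from compound 2 to compound 3 is a step that the limit leaves unreadable from compound 2 to compound 3, that is none beyond the scatter. Compound 3 is expected to give about 40000 nM in this assay, within 10000 nM to 100000 nM, and most probably the assay will again report only a limit.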

Compound 3, concentration for 50% growth inhibition: > 29400 nM
Compound 3 ended at the assay's limit; the forecaster's own chance of this, stated with the estimate: 80%; the middle value is on the limit's open side.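

In this assay compound 3 gives > 29400 nM, which is a limit and not a number. Compound 2 also stands only at a limit, so no step can be read for the change from methoxy to isobutoxy between compound 2 and compound 3. From the compounds shown here alone, with no number among compounds 1, 2 and 3, how any change to these structures moves growth inhibition stays open.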